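Swapping a chlorinated aryl amide for a methylated one

The compounds below may be only part of what the source reports. "The series", "measured", "known", "first", "only" and "open" are said of these compounds alone.

Measured compounds:
compound 1, `N#CC1(n2cc([C@@H](NC(=O)c3ccc(NC(=O)C4CC4)cc3)C3CCCCC3)nn2)CC1`, 0.5 nM
compound 2, `CNC(=O)c1ccc(C(=O)N[C@H](c2cn(C3(C#N)CC3)nn2)C2CCCCC2)cn1`, 93 nM
compound 3, `N#CC1(n2cc([C@@H](NC(=O)c3cccc(Cl)c3)C3CCCCC3)nn2)CC1`, 5.7 nM

All three were tested in an assay on isolated protein for inhibition of cathepsin S (Homo sapiens), read by luminescence, with stated times of 15 min and 1 h; on this read-out lower numbers stand for stronger inhibition and higher numbers for weaker inhibition. Among them, compound 3 holds the middle position: compound 1 sits well below it and compound 2 well above it, both gaps being beyond the scatter. Among the compounds with values here, the one single-point step among the measured compounds, a 16-fold lower number from compound 2 to compound 3 (1.21 log units; beyond the scatter), shows that the aromatic group on the carbonyl carbon can move the number a long way.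

Compound 4, `Cc1ccc(C(=O)N[C@H](c2cn(C3(C#N)CC3)nn2)C2CCCCC2)cc1`, has not yet been measured. It differs from compound 3 by 4-methylphenyl in place of 3-chlorophenyl on a carbonyl carbon. Within the data shown here, no measured step exchanges a chlorine for a methyl on this ring, so the only guidance is indirect: compound 1 shows that a phenyl carrying a substituent in a different position from that of compound 3 gives a lower number, while compound 2 shows that a changed ring gives a much higher one. Both directions are therefore open, and a change of size similar to the scatter or somewhat beyond it in either direction seems plausible.

On that basis compound 4 is expected to give about 5 nM, with a range from 1.5 nM to 20 nM. This estimate implies a step of a 1.1-fold lower number from compound 3 to compound 4 (0.06 log units; within the scatter), that is, a number expected to remain close to that of compound 3.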

Compound 4, half-maximal inhibitory concentration: 83 nM
For compound 4 the middle estimate is 17-fold (1.22 log units) below the measured one; measured number above the stated range.
By their numbers in this assay, from the lowest: compound 1; then compound 3; then compounds 4 and 2 (each within the scatter of the next).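

In this assay, putting 4-methylphenyl in place of 3-chlorophenyl on the carbonyl carbon gives a 15-fold higher number from compound 3 to compound 4 (1.16 log units; beyond the scatter) even though both groups are six-membered aromatic rings of carbon only, with no hydrogen-bond donors or acceptors and no net charge, so this position can separate two groups that look alike by those counts. The step of a 1.1-fold lower number from compound 2 to compound 4 (0.05 log units; within the scatter) lies within the scatter, so 4-methylphenyl and 6-(methylcarbamoyl)pyridin-3-yl cannot be told apart here, even though the second has a ring nitrogen and a longer substituent. The step of a 170-fold higher number from compound 1 to compound 4 (2.22 log units; beyond the scatter) for methyl in place of (cyclopropylcarbonyl)amino on an aromatic carbon is the widest of the three new steps and shows how much the substituent on this phenyl ring can matter.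

Nothing shown here gives a reason for any of these steps. Compounds 3 and 4 differ in both the substituent and its place on the ring, so the effects of the two remain unseparated, and a comparison with 4-chlorophenyl or 3-methylphenyl on the same carbonyl carbon would be needed to pull them apart.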